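Replacing an Acetamido Group: Expected Cell Toxicity of Compound 4

The source may hold more compounds than are shown below. What is called first, only, known or untested is meant among the compounds shown, and "the series" means these compounds.

Of the compounds shown here, three sharing one core have been tested in a toxicity assay on CCRF-CEM cells (Homo sapiens) for cytotoxicity; on this read-out lower numbers stand for higher toxicity in this test and higher numbers for lower toxicity in this test. Compound 1, `COc1cccc2c1nc(-c1c(F)cccc1F)n2Cc1c(F)cccc1F`, gives 44.3 uM. Compound 2, `CC(=O)Nc1cccc2c1nc(-c1c(F)cccc1F)n2Cc1c(F)cccc1F`, gives 39.3 uM, the lowest of the three numbers, though both neighbours lie within the usual scatter of it. Compound 3, `NCc1cccc2c1nc(-c1c(F)cccc1F)n2Cc1c(F)cccc1F`, gives 49.3 uM. The measured steps are all small: a 1.1-fold lower number from compound 1 to compound 2 (0.05 log units; within the scatter), a 1.1-fold higher number from compound 1 to compound 3 (0.05 log units; within the scatter), and a 1.3-fold higher number from compound 2 to compound 3 (0.10 log units; within the scatter). The unmeasured compound 4, `CC(=O)N(C)Cc1cccc2c1nc(-c1c(F)cccc1F)n2Cc1c(F)cccc1F`, differs from compound 2 in one place: (acetyl(methyl)amino)methyl in place of acetamido on an aromatic carbon. The step that bears most on this change is the one in which the acetamido was exchanged on the same aromatic carbon, a 1.3-fold higher number from compound 2 to compound 3 (0.10 log units; within the scatter), which stayed within the scatter; the step in which the acetamido entered, a 1.1-fold lower number from compound 1 to compound 2 (0.05 log units; within the scatter), did likewise. Since every exchange of the group on this aromatic carbon has so far left the number essentially unchanged, compound 4 is expected to show no step beyond the scatter in this assay, meaning a 1.1-fold higher number from compound 2 to compound 4 (0.03 log units; within the scatter). Compound 4 is therefore estimated at 42 uM, within a range from 24 uM to 75 uM.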

Compound 4, half-maximal toxic concentration: 20.6 uM
Compound 4: middle estimate off by 2.0-fold (0.31 log units), on the high side, and the stated range ends above it.
By their numbers in this assay, from the lowest: compounds 4, 2, 1 and 3 (each within the scatter of the next, the first and the last beyond it).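

On this aromatic carbon, a change of group can now move the number in this assay beyond the scatter: (acetyl(methyl)amino)methyl gives a 2.2-fold lower number from compound 1 to compound 4 (0.33 log units; beyond the scatter) against methoxy and a 2.4-fold lower number from compound 3 to compound 4 (0.38 log units; beyond the scatter) against aminomethyl, both modest steps, whereas no earlier exchange left the scatter. Against acetamido, the same group stays within the scatter, at a 1.9-fold lower number from compound 2 to compound 4 (0.28 log units; within the scatter), so compound 2 and compound 4 cannot be told apart in this test. Nothing shown here offers an explanation for these steps.

Going by these compounds, it remains open which part of the entering group goes with the lower number, since acetyl and methyl arrive together on the nitrogen. Acetamidomethyl or methylaminomethyl, each carrying only one of them, would separate the two, and a longer chain would show whether the trend continues.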